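Compound 3 and a bulkier group on the nitrogen

The compounds below may be only part of what the source reports. "The series", "measured", "known", "first", "only" and "open" are said of these compounds alone.

- Compound 1 `CCCCCNc1nc2cc(-c3ccc(C)cc3)sc2c(=O)[nH]1`: 4200 nM
- Compound 2 `CCCCCCNc1nc2cc(-c3ccc(C)cc3)sc2c(=O)[nH]1`: 10600 nM
- Compound 3 `Cc1ccc(-c2cc3nc(NCC(C)C)[nH]c(=O)c3s2)cc1`: 21600 nM

In an ADME assay on HepG2 cells (Homo sapiens) for cytotoxicity, read by MTT assay, with a stated time of 72 h (on this read-out higher numbers stand for lower toxicity in this test and lower numbers for higher toxicity in this test), compound 3 has the highest number of the three. Compound 4 `Cc1ccc(-c2cc3nc(NC(C)c4ccccc4)[nH]c(=O)c3s2)cc1` differs from it in one group: 1-phenylethyl in place of isobutyl on a nitrogen on an aromatic ring. The nearest evidence comes from changes to the same group: a 5.1-fold higher number from compound 1 to compound 3 (0.71 log units; beyond the scatter) and a 2.0-fold higher number from compound 2 to compound 3 (0.31 log units; beyond the scatter). Another modest change is a 2.5-fold higher number from compound 1 to compound 2 (0.40 log units; beyond the scatter). None of these steps adds a ring, so they guide the expectation only loosely. Compound 1 and compound 2 both sit lower than compound 3, so a modest fall is expected: a 2.4-fold lower number from compound 3 to compound 4 (0.38 log units; beyond the scatter). For compound 4 the estimated value is 9000 nM, with an expected range from 3000 nM to 25000 nM.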

Compound 4, half-maximal cytotoxic concentration: 9200 nM
Estimate against measurement, compound 4: 1.0-fold (0.01 log units) below; measured number inside the range.
By their numbers in this assay, from the lowest: compound 1; then compounds 4 and 2 (each within the scatter of the next); then compound 3.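

Placing a ring on this nitrogen is new: in this assay the change to 1-phenylethyl gives a 2.3-fold lower number from compound 3 to compound 4 (0.37 log units; beyond the scatter) and so does not keep the higher number seen with isobutyl. Against the straight chains, it gives a 2.2-fold higher number from compound 1 to compound 4 (0.34 log units; beyond the scatter) and also a 1.2-fold lower number from compound 2 to compound 4 (0.06 log units; within the scatter), so the ring-bearing group and hexyl cannot be told apart in this test. Nothing measured here explains these differences.

Still open, on these data alone, is how a benzyl group, or a 1-phenylethyl group carrying an amine on its ring, would read in this test. Also open, as far as these compounds go, is whether the ring or the branch in 1-phenylethyl counts for more.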